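From Phenoxy to Benzyl on the Amine Side Chain

This account rests on a few compounds, and the source may have more. Where it says the series, first, only, none or still open, it means among the compounds named here.

Within the data shown here, in a functional assay on MCF7 cells (Homo sapiens) for inhibition (on this read-out higher numbers stand for weaker inhibition and lower numbers for stronger inhibition), compound 1 `O=C(NO)c1ccc(-c2ccc(CNCc3ccc(Cl)cc3)cn2)s1` gives 130 nM and compound 2 `O=C(NO)c1ccc(-c2ccc(CNCCOc3ccccc3)cn2)s1` gives 110 nM, which places compound 2 within the scatter of its only measured neighbour. Compound 3 `O=C(NO)c1ccc(-c2ccc(CNCCCc3ccccc3)cn2)s1` carries benzyl in place of phenoxy on a saturated chain carbon, two bonds along the chain from an amine nitrogen. Among the measured compounds shown here, the one measured step, a 1.2-fold lower number from compound 1 to compound 2 (0.07 log units; within the scatter), also concerns this side chain and stayed within the scatter, so no change beyond the scatter is expected in this assay. Compound 3 is expected at 100 nM, with an estimated range of 45 nM to 220 nM. The expected change is a 1.1-fold lower number from compound 2 to compound 3 (0.04 log units; within the scatter).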

Compound 3, half-maximal inhibitory concentration: 120 nM
The estimate for compound 3 lay 1.2-fold (0.08 log units) below the measured number; the range from low to high includes it.
By their numbers in this assay, from the lowest: compounds 2, 3 and 1 (each within the scatter of the next).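

Benzyl in place of phenoxy gave a 1.1-fold higher number from compound 2 to compound 3 (0.04 log units; within the scatter) in this assay and so, on this saturated chain carbon, the exchange of a hydrogen-bond acceptor for none left the number within the scatter. The step of a 1.1-fold lower number from compound 1 to compound 3 (0.03 log units; within the scatter) also stays within the scatter, so the 4-chlorophenyl, phenoxymethyl and phenethyl side chains read alike here. No measurement available here bears on the reason for this. On these data alone, whether an amine or a carboxylic acid at the end of this side chain, or a longer chain, would move the number beyond the scatter remains open.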